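This account rests on a few compounds, and the source may have more. Where it says the series, first, only, none or still open, it means among the compounds named here.

In a functional assay (aorta) with Rattus norvegicus as the target (on this read-out higher numbers stand for an effect only at larger amounts of compound and lower numbers for an effect already at smaller amounts), compound 1 `COc1ccc(-c2nc(N=C(N)N)sc2-c2ccc(OC)cc2)cc1` gives 2 uM, and compound 2 `CNC(=N)Nc1nc(-c2ccc(OC)cc2)c(-c2ccc(OC)cc2)s1` gives 1.2 uM. With only these two numbers, compound 1 has no clear rank, as the two sit within the usual scatter of each other. Compound 3 `COc1ccc(-c2nc(/N=C(\N)NC(C)C)sc2-c2ccc(OC)cc2)cc1` keeps the core of compound 1 and alters one spot: isopropyl in place of hydrogen on an amine nitrogen. Among the measured compounds shown here, the one measured step that bears on this change also enlarges the same group, and it is small: a 1.7-fold lower number from compound 1 to compound 2 (0.22 log units; within the scatter). For the measured compounds named here, that is thin evidence, and no measured compound carries isopropyl, so the range has to stay wide. No change beyond the scatter is expected, and the estimated step is a 1.3-fold lower number from compound 1 to compound 3 (0.12 log units; within the scatter). For compound 3 the estimate is 1.5 uM, with an expected range from 0.5 uM to 5 uM.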

Compound 3, concentration for half-maximal effect: 9.1 uM
For compound 3 the middle estimate is 6.1-fold (0.78 log units) below the measured one; measured number above the stated range.
By their numbers in this assay, from the lowest: compounds 2 and 1 (each within the scatter of the next); then compound 3.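

In this assay, among the compounds shown here, this amine nitrogen does not take every added group alike: isopropyl in place of hydrogen gives a 4.6-fold higher number from compound 1 to compound 3 (0.66 log units; beyond the scatter), the first step in this set that lies beyond the scatter. The gap to the group carried by compound 2 is wider still, with a 7.6-fold higher number from compound 2 to compound 3 (0.88 log units; beyond the scatter). So a change at this spot can matter, since compound 2 stays within the scatter of compound 1 while compound 3 does not.

No measurement here accounts for the rise in the number. Going by these compounds, whether ethyl, a longer chain such as n-butyl or a ring such as cyclopropyl on this nitrogen would stay close to compound 1 or move as far as compound 3 remains open, so the single isopropyl result cannot yet be read as a trend.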